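The compounds below may be only part of what the source reports. "The series", "measured", "known", "first", "only" and "open" are said of these compounds alone.

Two members of the shared core have been run in a functional assay on the whole organism for antagonist activity, with Mus musculus as the target; a higher number here means that more compound is needed for the effect, a lower number that less compound is needed. Compound 1 `CN(C(=O)CNC(=O)CN)c1ccc(Cl)cc1C(=O)c1ccccc1Cl` gives 0.58 mg/kg. Among the compounds with values here, compound 2 `CC(C)C(=O)NCC(=O)N(C)c1ccc(Cl)cc1C(=O)c1ccccc1Cl` gives 6 mg/kg, the highest of the two numbers so far; the single measured step, a 10-fold higher number from compound 1 to compound 2 (1.01 log units; beyond the scatter), sets the gap between them. Compound 3 `CN(C)CC(=O)NCC(=O)N(C)c1ccc(Cl)cc1C(=O)c1ccccc1Cl` is the next member and has not yet been measured in this assay. The change from compound 2 is this: (dimethylamino)methyl in place of isopropyl on a carbonyl carbon. Within the data shown here, no measured step covers this exact change. Among the measured compounds shown here, the only step that bears on it is a 10-fold higher number from compound 1 to compound 2 (1.01 log units; beyond the scatter), in which the aminomethyl on the carbonyl carbon went with the lower number and isopropyl with the higher. Compound 3 again carries a nitrogen-bearing group on that carbonyl carbon, so a step back towards the number of compound 1 is expected, a 4.0-fold lower number from compound 2 to compound 3 (0.60 log units; beyond the scatter), though not necessarily the whole distance. For compound 3 a value of 1.5 mg/kg is expected, within 0.5 mg/kg to 5 mg/kg.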

Compound 3, dose for half-maximal effect: 2.6 mg/kg
Compound 3: middle estimate off by 1.7-fold (0.24 log units), on the low side; the measured number falls inside the stated range.
By their numbers in this assay, from the lowest: compound 1; then compound 3; then compound 2.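

In this assay, a second nitrogen-bearing group on this carbonyl carbon again goes with a lower number than isopropyl, with a 2.3-fold lower number from compound 2 to compound 3 (0.36 log units; beyond the scatter) on this change. The nitrogen alone does not carry the full effect, as dimethylamino in place of amino on the saturated chain carbon gives a 4.5-fold higher number from compound 1 to compound 3 (0.65 log units; beyond the scatter) in the same assay, so the substitution on that nitrogen also matters. Nothing in the available data gives a reason for either step.

On these data alone, whether methylamino on the same chain carbon would give a number nearer that of compound 1 or that of compound 3 remains open. Also open, as far as these compounds go, is whether a carboxylic acid or a longer chain ending in an amine on this carbonyl carbon would follow the same order.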